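Methyl in Place of Hydrogen on a Weak Starting Point

The source may report more compounds than this note shows. Statements on the series, on what has been measured and on what is new or still open speak of the compounds shown alone.

Compound 1, `COc1ncc(C#Cc2ccc(C)cc2)cn1`: "not active" (no number reported)
Compound 2, `CSc1ncc(C#Cc2ccccc2)cn1`: 120000 nM
Compound 3, `CSc1ncc(C#Cc2cccc(C)c2)cn1`: "not active" (no number reported)

Of the compounds shown here, three share a core and have been tested in an assay on HEK293 cells for positive allosteric modulation of metabotropic glutamate receptor 5 (Rattus norvegicus); a lower number here means that less compound is needed, a higher number that more compound is needed for the effect. Compound 2 is the only one of them that gives a number, and that number is 120000 nM, which means a large amount of compound is needed for the effect. Compound 1 is reported in this assay as "not active" (no number reported), and compound 3 is likewise reported as "not active" (no number reported); neither gives a number to compare against.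

Compound 4, `CSc1ncc(C#Cc2ccc(C)cc2)cn1`, has not yet been measured. It differs from compound 2 in one place: methyl in place of hydrogen on an aromatic carbon. For the measured compounds named here, the same methyl, on the same core but with a different group on the other ring, stands in compound 1, and a methyl on another carbon of the same ring stands in compound 3; both are reported without a number, so the two neighbours give no guide to the size of this step, and no measured pair shows it directly.

Given that compound 2 gives 120000 nM, compound 4 is expected to fall near 40000 nM, somewhere between 5000 nM and 150000 nM, a step of a 3.0-fold lower number from compound 2 to compound 4 (0.48 log units; beyond the scatter) that is expected to go toward less compound needed, though a result without a number remains a real possibility.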

Compound 4, half-maximal effective concentration: "not active" (no number reported)
Nothing numeric was reported for compound 4; no gap can be computed for the estimate.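

For the compounds shown here, compound 4 is reported as "not active" (no number reported) and compound 2 alone carries a number, so no step between these two compounds can be read. Nothing measured here offers an explanation for this result. The compounds shown leave open how much a methyl on the aromatic ring changes the amount of compound needed.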